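The compounds below may be only part of what the source reports. "The series", "measured", "known", "first", "only" and "open" are said of these compounds alone.

Working notes on the series in an ADME assay on Vero cells (Chlorocebus sabaeus) for cytotoxicity, read by MTT assay, with a stated time of 72 h; a lower number here means a stronger inhibitor, a higher number a weaker inhibitor.

The parent is compound 1 `Cc1c(C(=O)NCc2ccccc2)[n+]([O-])c2ccccc2[n+]1[O-]`. In this assay compound 1 gives > 100 ug/mL, which is a limit of the assay and not a number. Compound 2 `Cc1ccc2c(c1)[n+]([O-])c(C(=O)NCc1ccccc1)c(C)[n+]2[O-]` carries a methyl in place of hydrogen on an aromatic carbon of the fused ring. In this assay compound 2 gives > 100 ug/mL, again a limit. Compound 3 `COc1ccc(CNC(=O)c2c(C)[n+]([O-])c3ccccc3[n+]2[O-])cc1` carries a methoxy in place of hydrogen on the benzyl ring. In this assay compound 3 gives > 30 ug/mL, also a limit.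

Both measured steps are therefore unreadable: a step that the two limits leave unreadable from compound 1 to compound 2 and a step that the two limits leave unreadable from compound 1 to compound 3 cannot be sized, since the values on each side are limits. The picture is the limit of > 100 ug/mL in this assay, at which 2 of the 3 values shown sit, and (the limit of > 30 ug/mL in this assay, at which 1 of the 3 values shown sits); no measured value in the series is a number, and compound 3 stands at the lower of the two limits only.

Compound 4 `COc1ccc(CNC(=O)c2c(C)[n+]([O-])c3ccc(C)cc3[n+]2[O-])cc1` differs from compound 3 by methyl in place of hydrogen on an aromatic carbon. Among the compounds with values here, the same change is the one between compound 1 and compound 2, where both values sit at a limit, so no step beyond the scatter is suggested. For compound 4 the step that the limit leaves unreadable from compound 3 to compound 4 is expected to be nil within scatter. Compound 4 is estimated at 150 ug/mL, with a range from 50 ug/mL to 500 ug/mL, most likely again reported only as a limit.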

Compound 4, half-maximal inhibitory concentration: > 30 ug/mL
Compound 4: a limit, no number; the forecaster's own chance of this, stated with the estimate: 85%; the middle value does not contradict the limit.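

In this assay compound 4 gives > 30 ug/mL, which is a limit and not a number. The steps to compound 4 from compound 3 and from compound 2 cannot be read, as each joins two limits. The compounds shown leave open what size, if any, the methyl and methoxy changes have in this assay, where none of the four has a numerical value.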